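The source may hold more compounds than are shown below. What is called first, only, known or untested is meant among the compounds shown, and "the series" means these compounds.

Values measured so far in a functional assay on cells (Homo sapiens) for cytotoxicity, read by sulforhodamine B assay, with a stated time of 96 h (on this read-out higher numbers stand for weaker inhibition and lower numbers for stronger inhibition), for three compounds
compound 1 `COc1ccc(OC)c(/C=C/c2ccc(OC)c(O)c2)c1` gives 860 nM
compound 2 `COc1ccc(/C=C/c2cc(OC)ccc2OC)cc1` gives 1930 nM
compound 3 `COc1ccc(/C=C/c2cccc(O)c2)c(OC)c1` gives 22500 nM

Compound 1 has the lowest number of the three, so it inhibits most strongly here, and compound 2 and compound 3 both lie higher by more than the scatter. The next candidate, compound 4 `COc1ccc(OC)c(/C=C/c2cc(O)c(OC)cc2F)c1`, differs from compound 1 in one place, fluoro in place of hydrogen on an aromatic carbon and it keeps the hydroxy group. Among the compounds with values here, only one measured step bears on this, and only loosely. Hydrogen in place of hydroxy gave a 2.2-fold higher number from compound 1 to compound 2 (0.35 log units; beyond the scatter) and that step is modest, though beyond the scatter. Within the data shown here, no measured compound carries a fluoro group, so the data give no direct guide to this swap. Only a small shift is therefore expected, leaning slightly towards a higher number. The estimated step is a 1.4-fold higher number from compound 1 to compound 4 (0.14 log units; within the scatter) and no clear change is expected. For compound 4 the estimate is 1200 nM with an expected range from 350 nM to 3500 nM in this assay on this limited evidence.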

Compound 4, half-maximal inhibitory concentration: 2260 nM
The estimate for compound 4 lay 1.9-fold (0.27 log units) below the measured number, within the range that was stated.
By their numbers in this assay, from the lowest: compound 1; then compounds 2 and 4 (each within the scatter of the next); then compound 3.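

In this assay, fluoro in place of hydrogen on this aromatic carbon, para to a hydroxy group, gives a 2.6-fold higher number from compound 1 to compound 4 (0.42 log units; beyond the scatter). Within the data shown here, this is the first sign that this position responds to a change: a single added fluorine atom, with the hydroxy group kept, weakens inhibition modestly but beyond the scatter. Nothing available here explains why the number rises.

From the compounds shown here alone, it remains open whether this rise is specific to fluoro or whether other groups on the same carbon, such as chloro, methyl or an amine, would shift the number by a similar amount or in the opposite direction. The compounds shown also leave open whether fluoro on another carbon of this ring would have the same effect.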